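Cytotoxicity notes: aziridine and azetidine glycoside sulfonamides

A few compounds are considered here, and "the series" means these few. Any claim that something is new, unique, unknown or untested is made for them only; others in the source may bear on it.

Measured in a functional assay on A549 cells (Homo sapiens) for cytotoxicity, read by MTT assay, with a stated time of 48 h; on this read-out higher numbers stand for weaker inhibition and lower numbers for stronger inhibition:
Compound 1 `CCCCCCCC1C(CO[C@@H]2O[C@@H]3CO[C@H](c4ccccc4)O[C@@H]3[C@H](OCc3ccccc3)[C@H]2O)N1S(=O)(=O)c1ccc(C)cc1` gives 235000 nM.
Compound 2 `CCCC1(CO[C@@H]2O[C@@H]3CO[C@H](c4ccccc4)O[C@@H]3[C@H](OCc3ccccc3)[C@H]2OCc2ccccc2)CN1S(=O)(=O)c1ccc(C)cc1` gives 579000 nM.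

Compound 2 stands highest of the two numbers in this assay; the nearest is compound 1, whose lower number lies beyond the usual scatter. Compound 3 `Cc1ccc(S(=O)(=O)N2CC2(CO[C@@H]2O[C@@H]3CO[C@H](c4ccccc4)O[C@@H]3[C@H](OCc3ccccc3)[C@H]2OCc2ccccc2)c2ccccc2)cc1` differs from compound 2 by phenyl in place of propyl on a saturated ring carbon. Within the data shown here, no measured pair shows a change of this kind, so the expected step of a 1.4-fold lower number from compound 2 to compound 3 (0.16 log units; within the scatter) is taken as none beyond the scatter, with a slight lean toward a lower number. Compound 3 is therefore estimated at 400000 nM, within 150000 nM to 1100000 nM.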

Compound 3, half-maximal inhibitory concentration: 599000 nM
Estimate against measurement, compound 3: 1.5-fold (0.18 log units) below; low and high end bracket the measured number.
By their numbers in this assay, from the lowest: compound 1; then compounds 2 and 3 (each within the scatter of the next).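

In this assay phenyl in place of propyl on a saturated ring carbon of the three-membered non-aromatic ring with 1 nitrogen gives a 1.0-fold higher number from compound 2 to compound 3 (0.01 log units; within the scatter) and so leaves the number unchanged within the scatter. At this position, an aromatic ring and a short chain therefore read alike. Nothing available explains this result. On these data alone, whether a longer chain, an amine or a carboxylic acid at this position would shift the number remains open. Also open, as far as these compounds go, is whether any such group would bring the number well below those of this pair.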